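This account rests on a few compounds, and the source may have more. Where it says the series, first, only, none or still open, it means among the compounds named here.

Measured so far:
compound 1 `CCCCCCCOc1ccc(CCC(N)(CO)CO)cc1` — 0.014 mg/kg
compound 2 `CCCCCCCCc1ccc(CCC(N)CO)cc1` — > 10 mg/kg
compound 3 `C=CCC(N)(CO)CCc1ccc(OCCCCCCC)cc1` — 3.1 mg/kg

In a functional assay on the whole organism (spleen, spleen) with Rattus norvegicus as the target (a higher number here means that more compound is needed for the effect, a lower number that less compound is needed), compound 2 reaches only a limit, > 10 mg/kg, so no number stands for it; the limit of > 10 mg/kg in this assay, at which 1 of the 3 values shown sits, marks that boundary. Compound 1 gives 0.014 mg/kg, and compound 3 gives 3.1 mg/kg. Going by the values given here, the one measured step, a 220-fold higher number from compound 1 to compound 3 (2.35 log units; beyond the scatter), shows that removing a hydroxy from the chain carbon carrying the amine costs heavily in this assay.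

Compound 4 `CCCCCCCCc1ccc(CCC(N)(CCO)CCO)cc1` differs from compound 2 by a group of 8 heavy atoms (5 carbon, 1 nitrogen, 2 oxygen; no ring) in place of a group of 4 heavy atoms (2 carbon, 1 nitrogen, 1 oxygen; no ring), on a saturated chain carbon, two bonds along the chain from an aromatic carbon. The change adds a second hydroxyl-bearing arm, in the direction opposite to the loss seen in the step from compound 1 to compound 3, so a downward step is expected, though the arms are longer than in compound 1 and compound 2 starts from a limit. For compound 4 the expected value is 2 mg/kg (range 0.2 mg/kg to 10 mg/kg), an estimated step of an at least 5.0-fold lower number from compound 2 to compound 4 (0.69 log units; beyond the scatter).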

Compound 4, dose for 50% inhibition: > 10 mg/kg
Compound 4: a limit, no number; the forecaster's own chance of this, stated with the estimate: 30%; middle value at least 5.0-fold (0.69 log units) from the limit.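

Compound 2 and compound 4 both stand at a limit in this assay, so no step between them can be read: the limit of > 10 mg/kg in this assay, at which 2 of the 4 values shown sit.

The compounds shown leave open whether the group entering in compound 4 changes the required dose at all.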